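The source may report more compounds than this note shows. Statements on the series, on what has been measured and on what is new or still open speak of the compounds shown alone.

Compound 2, `CCN(CC)Cc1ccc(Nc2nc3ccccc3[nH]2)cc1O`, and compound 1, `CC(C)(C)NCc1cc(Cl)cc(Nc2nc3ccccc3[nH]2)c1O`, share a core; their results in an ADME assay on CHO cells (Cricetulus griseus) for inhibition, read by MTT assay (on this read-out higher numbers stand for weaker inhibition and lower numbers for stronger inhibition), are known only as limits. In this assay compound 2 gives > 50000 nM, which is a limit of the assay and not a number. In this assay compound 1 likewise gives > 50000 nM, again a limit. Among the compounds with values here, compound 2 therefore stands at the limit of > 50000 nM in this assay, at which 2 of the 2 values shown sit, alongside the one other value shown, and neither value can be placed above or below the other.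

Compound 3, `CCN(CC)Cc1ccc(Nc2nc3ccccc3n2Cc2ccc(C(F)(F)F)cc2)cc1O`, has not yet been tested. It differs from compound 2 by 4-(trifluoromethyl)benzyl in place of hydrogen on an aromatic nitrogen. No measured step between any two compounds is available, so no measured cause can be pointed to. For compound 3, a modest move toward stronger inhibition is expected, with an at least 1.6-fold lower number from compound 2 to compound 3 (0.22 log units; that floor lies within the scatter), though the outcome may again be a limit. Compound 3 is estimated at 30000 nM, within a range from 8000 nM to 60000 nM.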

Compound 3, half-maximal inhibitory concentration: 41500 nM
The estimate for compound 3 lay 1.4-fold (0.14 log units) below the measured number, and the stated range covers the measured number.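

In this assay, within the data shown here, compound 3 gives 41500 nM, the first value in this set that is a number and not a limit, so with 4-(trifluoromethyl)benzyl on the aromatic nitrogen the read-out falls within the measurable range. The change reads as an at least 1.2-fold lower number from compound 2 to compound 3 (0.08 log units; that floor lies within the scatter), and since that floor lies within the scatter, the step does not establish how large the move is. Compound 1 and compound 2 remain at a limit and not at a number: the limit of > 50000 nM in this assay, at which 2 of the 3 values shown sit.

As far as these compounds go, whether methyl, unsubstituted benzyl, or a benzyl carrying a carboxylic acid or an amine on the same nitrogen would also give a number remains open. From the compounds shown here alone, it is equally open whether 4-(trifluoromethyl)benzyl would give a number on the core of compound 1.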